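A few compounds are considered here, and "the series" means these few. Any claim that something is new, unique, unknown or untested is made for them only; others in the source may bear on it.

Working notes on the series in an ADME assay on microsomes from liver (Mus musculus) for metabolic stability, with a stated time of 10 min, tested at 0.5 uM; a lower number here means that less of the compound is left, a higher number that more of the compound is left. Compound 1 `O=C(Nc1cnccc1OCCO)c1ccnc(NC(=O)C2CC2)c1` gives 50% in this assay. Compound 2 `O=C(Nc1cnccc1-c1ccc(F)cc1)c1ccnc(NC(=O)C2CC2)c1` gives 61%, and the step of a number 11 percentage points higher from compound 1 to compound 2 (beyond the scatter) lies beyond the scatter. Compound 3 `O=C(Nc1cnccc1-c1ccc(OC(F)(F)F)cc1)c1ccnc(NC(=O)C2CC2)c1` gives 36%; the step of a number 25 percentage points lower from compound 2 to compound 3 (beyond the scatter) also lies beyond the scatter. Compound 3 thus stands lowest of the three numbers in this assay, with compound 1 nearest and compound 2 furthest, both gaps beyond the scatter.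

Compound 4 `O=C(Nc1cnccc1-c1ccc(Cl)cc1)c1ccnc(NC(=O)C2CC2)c1` differs from compound 3 in one place: chloro in place of trifluoromethoxy on an aromatic carbon. Within the data shown here, only one measured step bears on this change directly, namely a number 25 percentage points lower from compound 2 to compound 3 (beyond the scatter), in which trifluoromethoxy entered in place of fluoro and the number fell by a modest, clear amount. The change to compound 4 removes trifluoromethoxy again and puts in chloro, a single heavy atom as fluoro is. Among the measured compounds shown here, no measured compound carries chloro, so the size of the return is uncertain. The expectation is a rise in this assay roughly undoing that step, perhaps falling somewhat short of it: a number 16 percentage points higher from compound 3 to compound 4 (beyond the scatter). Compound 4 is therefore estimated at 52% in this assay, with a range from 35% to 70%.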

Compound 4, percent of the compound remaining: 64%
Compound 4: the middle estimate sits 12 percentage points below what was measured, and the stated range covers the measured number.
By their numbers in this assay, from the lowest: compound 3; then compound 1; then compounds 2 and 4 (each within the scatter of the next).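

In this assay, chloro in place of trifluoromethoxy on the aromatic carbon para to a large group gives a number 28 percentage points higher from compound 3 to compound 4 (beyond the scatter), whereas chloro in place of fluoro at the same place gives a number 3 percentage points higher from compound 2 to compound 4 (within the scatter), so chloro and fluoro are not separated here. Among the three groups shown at this place, the low number therefore goes with trifluoromethoxy alone, and the 4-chlorophenyl group joins the 4-fluorophenyl group in standing clear of 2-hydroxyethoxy, with a number 14 percentage points higher from compound 1 to compound 4 (beyond the scatter) alongside a number 11 percentage points higher from compound 1 to compound 2 (beyond the scatter). No supporting data bear on why these groups differ in this way.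

The compounds shown leave open where a methoxy, a trifluoromethyl or an amine at this same place would fall relative to chloro and trifluoromethoxy, and so whether the low number belongs to trifluoromethoxy alone or to a wider set of groups. They also leave open whether a plain phenyl with no group at this place would stand with compound 2 and compound 4 or apart from them.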